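Cytotoxicity notes: pyridothiazole diaminopyrimidine series, anilino variation

The source may hold more compounds than are shown below. What is called first, only, known or untested is meant among the compounds shown, and "the series" means these compounds.

Compound 2 `Cc1nc(NCC2CCN(C)CC2)nc(N[C@@H]2C[C@H](CO)[C@@H](O)[C@H]2O)c1-c1nc2cnccc2s1` sits level with its neighbours in an ADME assay on cells (Homo sapiens) for cytotoxicity, read by polymerase chain reaction, with a stated time of 3 days; a lower number here means that less compound is tolerated, a higher number that more compound is tolerated: compound 2 gives 25000 nM, compound 1 `Cc1nc(N)nc(N[C@@H]2C[C@H](CO)[C@@H](O)[C@H]2O)c1-c1nc2cnccc2s1` gives 25000 nM, and compound 3 `Cc1nc(N[C@@H](C)c2ccccc2)nc(N[C@@H]2C[C@H](CO)[C@@H](O)[C@H]2O)c1-c1nc2cnccc2s1` gives 25000 nM. The replacements already measured on this nitrogen were flat: no change at the digits printed from compound 1 to compound 2 (within the scatter), no change at the digits printed from compound 1 to compound 3 (within the scatter), and no change at the digits printed from compound 2 to compound 3 (within the scatter), all within the scatter.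

Compound 4 `Cc1ccc(C2(Nc3nc(C)c(-c4nc5cnccc5s4)c(N[C@@H]4C[C@H](CO)[C@@H](O)[C@H]4O)n3)CC2)cc1` differs from compound 2 by 1-(4-methylphenyl)cyclopropyl in place of (1-methylpiperidin-4-yl)methyl on a nitrogen on an aromatic ring. The flat steps from compound 1 to compound 2 and from compound 2 to compound 3 bear on it: neither a basic ring nor an aromatic group on this nitrogen moved this assay, so no step beyond the scatter is expected, no change at the digits printed from compound 2 to compound 4 (within the scatter). Compound 4 is therefore estimated at 25000 nM, with a range from 12500 nM to 50000 nM.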

Compound 4, half-maximal cytotoxic concentration: 25000 nM
For compound 4 middle estimate and measured number coincide at the digits printed; the range from low to high includes it.
By their numbers in this assay, from the lowest: compounds 1, 2, 3 and 4 (each within the scatter of the next).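

In this assay a group carrying both a three-membered non-aromatic ring and a six-membered aromatic ring, 1-(4-methylphenyl)cyclopropyl, enters on this nitrogen, and no change at the digits printed from compound 2 to compound 4 (within the scatter) and no change at the digits printed from compound 3 to compound 4 (within the scatter) and no change at the digits printed from compound 1 to compound 4 (within the scatter) all stand as the printed result. Across these four compounds, the read-out therefore stays the same with hydrogen or any of the three larger groups on this nitrogen. No supporting evidence bears on this result.

On these data alone, whether a carboxylic acid or a longer alkyl chain on this nitrogen would give a different number remains open.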